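The compounds below may be only part of what the source reports. "The series", "measured", "known", "first", "only" and "open" are said of these compounds alone.

In a functional assay on HL-60 cells (Homo sapiens), with a stated time of 2 days (on this read-out lower numbers stand for stronger inhibition and higher numbers for weaker inhibition), compound 2 `COc1ccc(CNC(=O)c2[nH]cnc2C(=O)Nc2ccc(Cl)c(Cl)c2)cc1` gives 24300 nM, the highest of the three numbers measured here. Compound 1 `O=C(NCc1ccccc1)c1nc[nH]c1C(=O)Nc1ccc(Cl)c(Cl)c1` gives 11500 nM and compound 3 `O=C(NCc1ccc(-c2ccccc2)cc1)c1nc[nH]c1C(=O)Nc1ccc(Cl)c(Cl)c1` gives 7000 nM. Among the measured compounds shown here, the single measured step, a 1.6-fold lower number from compound 1 to compound 3 (0.22 log units; within the scatter), concerns an aromatic carbon and not the amide-type nitrogen, so it does not bear on the change in question. For the measured compounds named here, compound 4 `C[C@@H](NC(=O)c1[nH]cnc1C(=O)Nc1ccc(Cl)c(Cl)c1)C(=O)OC(C)(C)C` carries 1-(tert-butoxycarbonyl)ethyl in place of 4-methoxybenzyl on an amide-type nitrogen, and no measured pair shows what exchanging the 4-methoxybenzyl group for a chain of this kind does in this assay. With nothing to lean on, the step is expected to be a 1.2-fold lower number from compound 2 to compound 4 (0.08 log units; within the scatter), with neither direction favoured beyond the scatter. Compound 4 is therefore estimated at 20000 nM, within a range from 5000 nM to 80000 nM.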

Compound 4, half-maximal inhibitory concentration: 4600 nM
Estimate against measurement, compound 4: 4.3-fold (0.64 log units) above, and the stated range ends above it.
By their numbers in this assay, from the lowest: compounds 4, 3 and 1 (each within the scatter of the next, the first and the last beyond it); then compound 2.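

In this assay, among the compounds shown here, 1-(tert-butoxycarbonyl)ethyl in place of 4-methoxybenzyl on the amide-type nitrogen gives a 5.3-fold lower number from compound 2 to compound 4 (0.72 log units; beyond the scatter), the only measured change at this nitrogen. An open chain with no ring and the same heavy-atom count can therefore stand at this position without any loss on this read-out. Nothing at hand accounts for the size of this step. On these data alone, whether the ester, the methyl branch or the defined stereocentre matters most stays open. So does what a free carboxylic acid in place of the tert-butyl ester would give.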